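The source may report more compounds than this note shows. Statements on the series, on what has been measured and on what is new or still open speak of the compounds shown alone.

Measured compounds:
- compound 1, `CCCc1cc2ccccc2nc1-c1cc(-c2ccccc2)no1`: in a functional assay on A549 cells (Homo sapiens) for inhibition, read by MTT assay, with a stated time of 24 h (a lower number here means a stronger inhibitor, a higher number a weaker inhibitor), compound 1 gives 52500 nM
- compound 2, `CCCc1cc2ccccc2nc1-c1cc(-c2ccc(F)cc2)no1`: compound 2 gives 51300 nM
- compound 3, `CCc1cc2ccccc2nc1-c1cc(-c2ccc(C)cc2)no1`: compound 3 gives > 100000 nM

Among the compounds with values here, compound 3 stands at a limit of this assay and not at a number, as the limit of > 100000 nM in this assay, at which 1 of the 3 values shown sits, records; it is the only one of the three so far to sit there. Compound 1 and compound 2 both give measured numbers, and the step of a 1.0-fold lower number from compound 1 to compound 2 (0.01 log units; within the scatter) shows that a fluoro in place of hydrogen on an aromatic carbon leaves the read-out where it was.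

Compound 4, `CCCc1cc2ccccc2nc1-c1cc(-c2ccc(C)cc2)no1`, is not yet measured. Within the data shown here, it differs from compound 3 by methyl in place of hydrogen on a saturated chain carbon, two bonds along the chain from an aromatic carbon; no measured step touches the saturated chain, so the only pair that bears on the change is the comparison of compound 3 with compound 1 and compound 2, which carry the propyl chain and read below the limit, while compound 3 with the ethyl chain reads only as a limit. Among the measured compounds shown here, the single measured step, from compound 1 to compound 2, is within the scatter and speaks to the aromatic ring, not to the chain. Compound 4 is therefore expected to move from the limit of compound 3 towards the region of compound 1 and compound 2, a step estimated as an at least 1.2-fold lower number from compound 3 to compound 4 (0.09 log units; that floor lies within the scatter), though a fresh limit cannot be excluded. The estimate for compound 4 in this assay is 80000 nM, with a range from 35000 nM to 200000 nM.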

Compound 4, half-maximal inhibitory concentration: > 100000 nM
Compound 4: no number, only a limit; the forecaster's own chance of this, stated with the estimate: 40%; middle value at least 1.2-fold (0.09 log units) from the limit.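

In this assay, within the data shown here, compound 4 gives only a limit (> 100000 nM), so the propyl chain alone does not secure a measured number, which the earlier compounds could not show. With the propyl chain kept, exchanging hydrogen for methyl on an aromatic carbon gives an at least 1.9-fold higher number from compound 1 to compound 4 (0.27 log units; that floor lies within the scatter) and methyl in place of fluoro on that carbon gives an at least 1.9-fold higher number from compound 2 to compound 4 (0.28 log units; that floor lies within the scatter); both floors lie within the scatter, so neither step is yet shown to go beyond it, though fluoro and hydrogen give measured numbers where methyl gives a limit. The step between the ethyl and propyl compounds, compound 3 and compound 4, cannot be read, so the effect of the chain remains unknown, and the limit now accounts for a larger share of the series: the limit of > 100000 nM in this assay, at which 2 of the 4 values shown sit.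

As far as these compounds go, how far compound 3 and compound 4 lie beyond the measured compounds remains open, and so does whether the methyl group itself is responsible for the limit. From the compounds shown here alone, it is also open whether an amine or a carboxylic acid on that aromatic carbon, or a butyl chain in place of propyl, would give a measured number in this assay.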